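The source may report more compounds than this note shows. Statements on the series, on what has been measured and on what is new or still open speak of the compounds shown alone.

Working notes on the series. Compound 1 `NC(=O)N1CCN(C(=S)SCc2cn(Cc3ccc(F)cc3)nn2)CC1` carries fluoro on an aromatic carbon; compound 2 `NC(=O)N1CCN(C(=S)SCc2cn(Cc3ccc(Cl)cc3)nn2)CC1` carries chloro at the same place. In a functional assay on MCF7 cells (Homo sapiens) for cytotoxicity, read by MTT assay, with a stated time of 72 h (a higher number here means a weaker inhibitor, a lower number a stronger inhibitor), compound 1 gives 22100 nM. In this assay compound 2 gives only > 128000 nM, which is a limit of the assay and not a number. Among the measured compounds shown here, the one measured step, an at least 5.7-fold higher number from compound 1 to compound 2 (0.76 log units; beyond the scatter), is itself bounded by the limit of > 128000 nM in this assay, at which 1 of the 2 values shown sits, so where compound 2 truly stands is open beyond that limit. Compound 3 `COc1ccc(Cn2cc(CSC(=S)N3CCN(C(N)=O)CC3)nn2)cc1` takes the next step: methoxy in place of chloro on an aromatic carbon. For the measured compounds named here, no measured step joins chloro to methoxy, and the only step at hand, from fluoro to chloro, was at least modest toward a weaker inhibitor. With the starting point known only as a limit, the direction for compound 3 cannot be read from the measured steps; a number between that of compound 1 and the limit is the working expectation. Compound 3 is expected to show a step of an at least 2.1-fold lower number from compound 2 to compound 3 (0.32 log units; beyond the scatter) in this assay, giving an estimate of 60000 nM, within 15000 nM to 200000 nM.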

Compound 3, half-maximal inhibitory concentration: > 128000 nM
Compound 3: no number, only a limit; the forecaster's own chance of this, stated with the estimate: 40%; middle value at least 2.1-fold (0.32 log units) from the limit.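

In this assay, methoxy in place of fluoro at this position gives an at least 5.7-fold higher number from compound 1 to compound 3 (0.76 log units; beyond the scatter), so the move away from compound 1 no longer rests on chloro alone. Among the compounds shown, fluoro is the only group at this position with a measured number, while chloro and methoxy, which differ in heavy atoms and hydrogen-bond acceptors, both end at a limit of the assay. On these data alone, the step between compound 2 and compound 3 cannot be read, and their order remains unknown because both values end at the same limit: the limit of > 128000 nM in this assay, at which 2 of the 3 values shown sit.

Open, as far as these compounds go, is whether a hydroxyl, an amine or a nitrile at this position would give a measured number in this assay. Also open, from the compounds shown here alone, is whether a bromo group would follow fluoro or chloro there.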